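The compounds below may be only part of what the source reports. "The series", "measured", "known", "first", "only" and "open" are said of these compounds alone.

Measured so far:

Compound 1, `Cc1ccc(S(=O)(=O)/N=C(/CCNC2=CC(=O)c3ccccc3C2=O)Nc2ccc(F)cc2)cc1`, in a functional assay on HeLa cells (Homo sapiens) for cytotoxicity, read by MTT assay, with a stated time of 48 h (a lower number here means a stronger inhibitor, a higher number a weaker inhibitor), gives 5890 nM.
Compound 2, `COc1ccc(N/C(CCNC2=CC(=O)c3ccccc3C2=O)=N\S(=O)(=O)c2ccc(C)cc2)c(OC)c1`, in this assay gives 67600 nM.

Going by the values given here, compound 2 stands at the highest number of the two, with compound 1 the nearest; the only step, an 11-fold higher number from compound 1 to compound 2 (1.06 log units; beyond the scatter), separates them, and it is beyond the scatter.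

Compound 3, `Cc1ccc(S(=O)(=O)/N=C(/CCNC2=CC(=O)c3ccccc3C2=O)Nc2ccc(Cl)cc2Cl)cc1`, differs from compound 2 by 2,4-dichlorophenyl in place of 2,4-dimethoxyphenyl on an amine nitrogen. Among the compounds with values here, the one measured step bears on it only indirectly: it shows that exchanging the aryl group on this amine nitrogen can move the number a great deal in this assay, and that a halogen-bearing ring at this site gave the lower number. On that basis a large step downward from compound 2 to compound 3 is expected, though its size is uncertain. For compound 3 the expected value in this assay is 9000 nM, with a range from 2500 nM to 35000 nM. This estimate means an expected step of a 7.5-fold lower number from compound 2 to compound 3 (0.88 log units; beyond the scatter).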

Compound 3, half-maximal inhibitory concentration: 20500 nM
Estimate against measurement, compound 3: 2.3-fold (0.36 log units) below; the measured number falls inside the stated range.
By their numbers in this assay, from the lowest: compound 1; then compound 3; then compound 2.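

On the amine nitrogen, 2,4-dichlorophenyl in place of 2,4-dimethoxyphenyl gives a 3.3-fold lower number from compound 2 to compound 3 (0.52 log units; beyond the scatter) in this assay, so a change at this position can lower the number without reaching the value of compound 1. The second step, a 3.5-fold higher number from compound 1 to compound 3 (0.54 log units; beyond the scatter) for 2,4-dichlorophenyl in place of 4-fluorophenyl, shows that the two halogen-bearing aryl groups are not interchangeable here, and compound 1 remains the lowest of the three. Nothing available explains this order of the three aryl groups.

The compounds shown leave open whether the gap between compound 1 and compound 3 follows the kind of halogen or the number of ring substituents, which 4-chlorophenyl and 2,4-difluorophenyl on this nitrogen would help separate. Also open, as far as these compounds go, is how an unsubstituted phenyl or a cyclohexyl group would behave at this position.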